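From Methoxy to Hydrogen on the Aromatic Ring

A few compounds are considered here, and "the series" means these few. Any claim that something is new, unique, unknown or untested is made for them only; others in the source may bear on it.

Two measured compounds open the account. Compound 1 `COc1cccc(N2CCN(C(=O)C(C)N3C(=O)CCC3=O)CC2)c1` and compound 2 `COCC(C(=O)N1CCN(c2cccc(C(F)(F)F)c2)CC1)N1C(=O)CCC1=O` were both tested in a functional assay on the whole organism (strain Swiss) with Mus musculus as the target, in the maximal electroshock model, with a stated time of 0.5 h, at a dose of 300 mg/kg by the intraperitoneal route; a lower number here means a weaker effect, a higher number a stronger effect of the compound at the dose given. In this assay compound 1 gives 50%, and in the same test compound 2 gives 50%. Compound 1 thus stands level with compound 2 at the digits shown; the two values sit within the scatter of each other, so neither can be placed above the other. Within the data shown here, no two measured compounds differ in a single place, so no measured step is available to anchor what a single change does.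

Compound 3 `CC(C(=O)N1CCN(c2ccccc2)CC1)N1C(=O)CCC1=O` is the compound still to be measured. It differs from compound 1 by hydrogen in place of methoxy on an aromatic carbon. Among the measured compounds shown here, nothing among the measured compounds speaks to this change, since compound 2 is altered in more than one place relative to compound 1. The step is therefore expected to be small, if anything a mild loss that may not rise beyond the scatter, the expected step being a number 10 percentage points lower from compound 1 to compound 3 (within the scatter). For compound 3 in this assay the estimate is 40%, with a range from 20% to 60%.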

Compound 3, a percentage reported as activity, at one dose (the size of the read-out at that dose, not a potency): 50%
The estimate for compound 3 lay 10 percentage points below the measured number; measured number inside the range.
By their numbers in this assay, from the lowest: compounds 1, 2 and 3 (each within the scatter of the next).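

In this assay, among these compounds, hydrogen in place of methoxy on the aromatic carbon gives no change at the digits printed from compound 1 to compound 3 (within the scatter), and this is the first step that changes a single place. Among the compounds shown here, at this one dose, the 3-methoxyphenyl group can therefore give way to phenyl without a readable difference, which shows that the methoxy group is not required for the level of effect seen in this pair, whereas the earlier compounds could not address this question. Nothing at hand explains why this position accepts the change.

Compound 2 differs from both of the other compounds in more than one place, so its steps cannot be read, and the part played by the rest of the core remains unresolved. As far as these compounds go, it also remains open whether a different group on this aromatic carbon, such as an amine, a carboxylic acid or a longer alkoxy chain, would hold the same level, and whether the equal read-outs at this single dose and time would persist at lower doses.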